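Lengthening a Dimethylamino Chain: Compound 2 to Compound 3

This account rests on a few compounds, and the source may have more. Where it says the series, first, only, none or still open, it means among the compounds named here.

Compound 1 `Cn1c(N)c(-c2nc3ccccc3[nH]2)c2nc(C#N)c(C#N)nc21` sits at the limit of an ADME assay on HEK293 cells (Homo sapiens) for cytotoxicity, read by MTT assay, with a stated time of 48 h; a higher number here means a weaker inhibitor, a lower number a stronger inhibitor: compound 1 gives > 50000 nM, a limit rather than a number (the limit of > 50000 nM in this assay, at which 1 of the 2 values shown sits). Within the data shown here, compound 2 `CN(C)CCn1c(N)c(-c2nc3ccccc3[nH]2)c2nc(C#N)c(C#N)nc21` holds the only measured number, 9730 nM, reached by an at least 5.1-fold lower number from compound 1 to compound 2 (0.71 log units; beyond the scatter). Compound 3 `CN(C)CCCn1c(N)c(-c2nc3ccccc3[nH]2)c2nc(C#N)c(C#N)nc21` differs from compound 2 by (dimethylamino)methyl in place of dimethylamino on a saturated chain carbon, two bonds along the chain from an aromatic nitrogen. Among the measured compounds shown here, the single measured step concerns adding the dimethylamino chain, not extending it, so it gives no direct guide here. Compound 3 is therefore expected to stay within the scatter of compound 2, a 1.2-fold lower number from compound 2 to compound 3 (0.09 log units; within the scatter). The estimate for compound 3 in this assay is 8000 nM, between 3500 nM and 20000 nM.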

Compound 3, half-maximal inhibitory concentration: 8360 nM
Estimate against measurement, compound 3: 1.0-fold (0.02 log units) below, within the range that was stated.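

In this assay, going from 2-(dimethylamino)ethyl to 3-(dimethylamino)propyl on the aromatic nitrogen gives a 1.2-fold lower number from compound 2 to compound 3 (0.07 log units; within the scatter), so at this position the two chains read alike. The longer chain also gives an at least 5.9-fold lower number from compound 1 to compound 3 (0.77 log units; beyond the scatter), so both dimethylamino chains stand apart from compound 1. That step has no fixed size, as compound 1 sits at a limit: the limit of > 50000 nM in this assay, at which 1 of the 3 values shown sits.

On these data alone, whether a longer chain would keep this reading remains open. So does whether a morpholine or a carboxylic acid at the chain end would do the same.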